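Triazole aryl variation at the antiproliferative limit

The source may hold more compounds than are shown below. What is called first, only, known or untested is meant among the compounds shown, and "the series" means these compounds.

Compound 3 `Cc1ccc(-n2nncc2CN2C(=O)C3(C(C#N)=C(N)Oc4c3c3nc5ccccc5nc3c3ccccc43)c3ccccc32)cc1C` sits at a limit of an ADME assay on HUVEC cells (Homo sapiens) for antiproliferative activity, read by MTT assay, with a stated time of 48 h; a lower number here means a stronger inhibitor, a higher number a weaker inhibitor; in this assay compound 3 gives > 50000 nM, a limit rather than a number. Compound 1 `COc1ccccc1-n1nncc1CN1C(=O)C2(C(C#N)=C(N)Oc3c2c2nc4ccccc4nc2c2ccccc32)c2ccccc21` also reaches only a limit in this assay, giving > 50000 nM. Compound 2 `N#CC1=C(N)Oc2c(c3nc4ccccc4nc3c3ccccc23)C12C(=O)N(Cc1cnnn1-c1cccc(S(N)(=O)=O)c1)c1ccccc12` gives 38600 nM in this assay. The measured steps are an at least 1.2-fold lower number from compound 1 to compound 2 (0.11 log units; that floor lies within the scatter), an at least 1.2-fold higher number from compound 2 to compound 3 (0.11 log units; that floor lies within the scatter) and a step that the two limits leave unreadable from compound 1 to compound 3; given (the limit of > 50000 nM in this assay, at which 2 of the 3 values shown sit), no change of the aryl group on the aromatic nitrogen moves this assay beyond the scatter. Compound 4 `Cc1ccc(C)c(-n2nncc2CN2C(=O)C3(C(C#N)=C(N)Oc4c3c3nc5ccccc5nc3c3ccccc43)c3ccccc32)c1` differs from compound 3 by 2,5-dimethylphenyl in place of 3,4-dimethylphenyl on an aromatic nitrogen. Compound 4 is therefore expected to remain at the limit, an estimated step that the limit leaves unreadable from compound 3 to compound 4. The estimate for compound 4 is 55000 nM, between 25000 nM and 150000 nM.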

Compound 4, half-maximal inhibitory concentration: > 50000 nM
Compound 4 ended at the assay's limit; the forecaster's own chance of this, stated with the estimate: 70%; the middle value does not contradict the limit.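

In this assay compound 4 gives > 50000 nM as a limit and not a number, so 2,5-dimethylphenyl in place of 3,4-dimethylphenyl on the aromatic nitrogen yields no readable change. Steps between compounds at the limit cannot be read, and the one readable step is an at least 1.2-fold higher number from compound 2 to compound 4 (0.11 log units; that floor lies within the scatter) and does not separate 2,5-dimethylphenyl from 3-sulfamoylphenyl. Moving the methyl groups thus adds one more aryl group at the limit: the limit of > 50000 nM in this assay, at which 3 of the 4 values shown sit.

Still open, as far as these compounds go, is whether any aryl group here can give a value clear of the limit. An amine or a carboxylic acid on the phenyl ring in place of the methyl groups remains untested in the compounds shown.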